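The source may hold more compounds than are shown below. What is called first, only, known or untested is meant among the compounds shown, and "the series" means these compounds.

Measured so far in a functional assay on MDA-MB-231 cells (Homo sapiens) for cytotoxicity, read by sulforhodamine B assay, with a stated time of 48 h; a higher number here means a weaker inhibitor of growth, a lower number a stronger inhibitor of growth:

Compound 1 `Cc1ccc(-c2ccc(C)n2-c2ccc(-c3nc4ccc(F)cc4s3)cc2)cc1` gives 3140 nM.
Compound 2 `COc1ccc2nc(-c3ccc(-n4c(C)ccc4-c4ccc(C)cc4)cc3)sc2c1` gives 4010 nM.
Compound 3 `COc1ccc2nc(-c3ccc(-n4c(C)ccc4-c4ccc(F)cc4)cc3)sc2c1` gives 4060 nM.

The three share one core, and the changes between them are small. Compound 2 differs from compound 1 by methoxy in place of fluoro on an aromatic carbon, and the measured step is a 1.3-fold higher number from compound 1 to compound 2 (0.11 log units; within the scatter). Compound 3 differs from compound 2 by fluoro in place of methyl on an aromatic carbon, and that step is a 1.0-fold higher number from compound 2 to compound 3 (0.01 log units; within the scatter). The three numbers therefore sit close together in this assay, with no ordering that the scatter would support.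

Compound 4 `COc1ccc(-c2ccc(C)n2-c2ccc(-c3nc4ccc(OC)cc4s3)cc2)cc1` has not yet been measured. It differs from compound 3 by methoxy in place of fluoro on an aromatic carbon. Going by the values given here, this is the same kind of change as the one from compound 1 to compound 2, but not the same change: there the ring carrying it is part of a fused or bridged system of two rings, meta to a fused ring and para to a fused ring, whereas here the ring is of carbon only and the group sits para to a large group. How the core of compound 3 differs from that of compound 1 is not broken down here.

Because a 1.3-fold higher number from compound 1 to compound 2 (0.11 log units; within the scatter) lies within the scatter, a small step is expected here too. The step this estimate means is a 1.1-fold higher number from compound 3 to compound 4 (0.02 log units; within the scatter), expected to stay within the scatter. Compound 4 is thus estimated to give 4300 nM in this assay, most likely between 2000 nM and 9000 nM.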

Compound 4, concentration for 50% growth inhibition: 4120 nM
Compound 4: middle estimate off by 1.0-fold (0.02 log units), on the high side, within the range that was stated.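

In this assay, putting methoxy in place of fluoro, which turns 4-fluorophenyl into 4-methoxyphenyl, gives a 1.0-fold higher number from compound 3 to compound 4 (0.01 log units; within the scatter), and putting methoxy in place of methyl at the same place gives a 1.0-fold higher number from compound 2 to compound 4 (0.01 log units; within the scatter). Methoxy in place of fluoro can now be read on two cores, and the two readings do not differ: the same change on two cores in this assay, a 1.3-fold higher number (0.11 log units; within the scatter) from compound 1 to compound 2 and a 1.0-fold higher number (0.01 log units; within the scatter) from compound 3 to compound 4, 1.3-fold (0.10 log units) apart, within the scatter of two such steps This shows only that the change stayed small on both of these cores; with no step beyond the scatter to carry across, it does not show that a real effect of the change transfers from one core to another, and two cases make no general rule.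

The compounds shown carry only fluoro, methyl and methoxy at the places that change, so it remains open whether an amine, a carboxylic acid or a longer chain at those places would give a step beyond the scatter. Going by these compounds alone, also open is whether the methyl that stays the same on the shared core in all four compounds matters, since no step among them touches it.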